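A few compounds are considered here, and "the series" means these few. Any claim that something is new, unique, unknown or untested is made for them only; others in the source may bear on it.

compound 1 `COc1ccccc1-c1csc2cnc(Nc3ccc(NC(=O)[C@@H]4CCCNC4)cc3)nc12` gives 410 nM in a functional assay on MDA-MB-231 cells (Homo sapiens) for inhibition, read by MTT assay, with a stated time of 72 h; on this read-out lower numbers stand for stronger inhibition and higher numbers for weaker inhibition
compound 2 `COc1ccccc1-c1csc2cnc(Nc3ccc(C(=O)NC4CCNCC4)c(C)c3)nc12` gives 240 nM in this assay
compound 3 `COc1ccccc1-c1csc2cnc(Nc3ccc(C(=O)NC4CCNCC4)cc3C)nc12` gives 3240 nM in this assay

Compound 1 (410 nM) lies within the usual scatter of compound 2 (240 nM). Compound 3 (3240 nM) stands well beyond that scatter from compound 1, with a clearly weaker reading.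

The unmeasured compound 4 `CNC(=O)c1ccc(Nc2ncc3scc(-c4ccccc4OC)c3n2)cc1` keeps the core of compound 1 and changes one group, on an aromatic carbon of a six-membered aromatic ring of carbon only, para to a large group: methylcarbamoyl in place of ((piperidin-3-yl)carbonyl)amino (methylcarbamoyl in place of ((piperidin-3-yl)carbonyl)amino on an aromatic carbon).

For the measured compounds named here, no measured pair shows this exchange, so any expectation here is loose. All three measured compounds carry a six-membered non-aromatic ring with one hetero atom, and compound 4 has none. A move beyond the scatter towards higher numbers in this assay therefore seems likely, though the size is uncertain. The estimated change is a 6.1-fold higher number from compound 1 to compound 4 (0.79 log units; beyond the scatter) (weaker inhibition). Compound 4 is expected at 2500 nM (estimated range 600 nM to 10000 nM).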

Compound 4, half-maximal inhibitory concentration: 2120 nM
Compound 4: middle estimate off by 1.2-fold (0.07 log units), on the high side; measured number inside the range.
By their numbers in this assay, from the lowest: compounds 2 and 1 (each within the scatter of the next); then compounds 4 and 3 (each within the scatter of the next).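

In this assay, putting methylcarbamoyl in place of ((piperidin-3-yl)carbonyl)amino on this aromatic carbon, para to a large group, gives a 5.2-fold higher number from compound 1 to compound 4 (0.71 log units; beyond the scatter), so weaker inhibition goes with the smaller group, but inhibition is not lost. This single exchange changes several things at once: the six-membered non-aromatic ring and the defined stereocentre leave, and the amide is attached to the aromatic ring through its carbonyl rather than through its nitrogen, so the step cannot be pinned on any one of them. Nothing measured here explains the rise in the number.

Going by these compounds, it remains open whether the ring nitrogen or the ring carbons matter more. A cyclohexyl ring in place of the piperidine, or a longer chain ending in an amine, would help separate the two.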